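Replacing 1-acetylpiperidin-4-yl in compound 3 with an aromatic ring

The compounds below may be only part of what the source reports. "The series", "measured", "known", "first", "only" and "open" are said of these compounds alone.

In a physicochemical assay for lipophilicity, using the shake flask method, in phosphate buffer, measured as octanol-water partition, with a stated time of 30 min, at pH 7.4 (on this read-out higher numbers stand for higher lipophilicity and lower numbers for lower lipophilicity), compound 3 `CC(=O)N1CCC(c2cnc(NCc3c(F)ccc4c3CCO4)c3cn[nH]c(=O)c23)CC1` gives 2.9 with compound 1 `Cn1nccc1-c1cnc(NCc2c(F)ccc3c2CCO3)c2cn[nH]c(=O)c12` at 2.6 and compound 2 `O=C1CCCN1c1cnc(NCc2c(F)ccc3c2CCO3)c2cn[nH]c(=O)c12` at 1.8 in this series. The steps that end at this value are a number 0.30 log units higher from compound 1 to compound 3 (within the scatter) and a number 1.10 log units higher from compound 2 to compound 3 (beyond the scatter) on this read-out. Compound 4 `Cc1ncc(-c2cnc(NCc3c(F)ccc4c3CCO4)c3cn[nH]c(=O)c23)n1C` awaits measurement, with 1,2-dimethyl-1H-imidazol-5-yl in place of 1-acetylpiperidin-4-yl on an aromatic carbon. Compound 1 carries the closest measured group, 1-methyl-1H-pyrazol-5-yl, so the step of a number 0.30 log units higher from compound 1 to compound 3 (within the scatter) bears most directly and a number 0.80 log units lower from compound 1 to compound 2 (beyond the scatter) shows how far an exchange at this place can move the number. A modest downward move beyond the scatter is therefore expected. The expected step is a number 0.80 log units lower from compound 3 to compound 4 (beyond the scatter) on this evidence. For compound 4 the estimate is 2.1 within an expected range of 1.6 to 2.6 once measured.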

Compound 4, distribution coefficient: 1.9
Beside the measured number, compound 4's estimate is 0.20 log units above it; measured number inside the range.
By their numbers in this assay, from the lowest: compounds 2 and 4 (each within the scatter of the next); then compounds 1 and 3 (each within the scatter of the next).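

In this assay, an aromatic group at this place does not settle the number: 1,2-dimethyl-1H-imidazol-5-yl in place of 1-methyl-1H-pyrazol-5-yl gives a number 0.70 log units lower from compound 1 to compound 4 (beyond the scatter), and in place of 1-acetylpiperidin-4-yl gives a number 1.00 log units lower from compound 3 to compound 4 (beyond the scatter). Against the non-aromatic 2-oxopyrrolidin-1-yl it gives a number 0.10 log units higher from compound 2 to compound 4 (within the scatter), so aromatic and non-aromatic rings do not separate these four compounds. Nothing available here accounts for these differences.

Open, on these data alone, is where an amine or a carboxylic acid on this aromatic carbon would fall. Also open, as far as these compounds go, is whether 1-methyl-1H-imidazol-5-yl, lacking the second methyl, would stay level with compound 4.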